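A few compounds are considered here, and "the series" means these few. Any claim that something is new, unique, unknown or untested is made for them only; others in the source may bear on it.

Measured in a functional assay on SW-620 cells (Homo sapiens) for cytotoxicity, read by MTT assay, with a stated time of 72 h; on this read-out lower numbers stand for stronger inhibition and higher numbers for weaker inhibition:
compound 1 `COc1cccc(/C=C2\CCC/C(=C\c3cccc(Cl)c3)C2=O)c1OC`: 9100 nM
compound 2 `COc1cccc(/C=C2\CCC/C(=C\c3ccc(Cl)cc3)C2=O)c1OC`: 11100 nM
compound 3 `COc1cccc(/C=C2\CCC/C(=C\c3cccc(Br)c3)C2=O)c1OC`: 8800 nM

Compound 3 , at 8800 nM, stands within the scatter of both other compounds, so the three values form one level. The next compound to be read is compound 4 `COc1ccccc1/C=C1\CCC/C(=C\c2cccc(OC)c2OC)C1=O`, and the change is 2-methoxyphenyl in place of 3-bromophenyl on a double-bonded chain carbon bound to a double-bonded ring carbon. For the measured compounds named here, three measured steps bear on it, and all are small: a 1.0-fold lower number from compound 1 to compound 3 (0.01 log units; within the scatter), a 1.2-fold higher number from compound 1 to compound 2 (0.09 log units; within the scatter) and a 1.3-fold lower number from compound 2 to compound 3 (0.10 log units; within the scatter). Each lies within the scatter. Going by the values given here, exchanging the halogen or the chlorophenyl form at this place has therefore not moved the number so far. None of these steps tests a 2-methoxyphenyl group, so the evidence is indirect and the range must stay wide. In this assay no shift beyond the scatter is expected, and no direction is favoured: the expected step is a 1.0-fold higher number from compound 3 to compound 4 (0.01 log units; within the scatter). For compound 4 the estimated value is 9000 nM, with an expected range of 3500 nM to 22000 nM.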

Compound 4, half-maximal inhibitory concentration: > 20000 nM
Compound 4: a limit, no number (the forecaster's own chance of this, stated with the estimate: 5%); middle value at least 2.2-fold (0.34 log units) from the limit.
By their numbers in this assay, from the lowest: compounds 3, 1 and 2 (each within the scatter of the next). At a limit, above all of these: compound 4.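

In this assay the value of compound 4 is a limit of the assay and not a number: the limit of > 20000 nM in this assay, at which 1 of the 4 values shown sits. For the compounds shown here, the chlorophenyl and bromophenyl groups at this place read within the scatter of one another, whereas 2-methoxyphenyl gives the first steps beyond it: an at least 2.2-fold higher number from compound 3 to compound 4 (0.35 log units; beyond the scatter) and an at least 2.1-fold higher number from compound 1 to compound 4 (0.34 log units; beyond the scatter). The third comparison settles less, as its floor does not clear the scatter: an at least 1.8-fold higher number from compound 2 to compound 4 (0.25 log units; that floor lies within the scatter).

The limit leaves open how large these steps really are, and whether they belong to the methoxy group itself or to where it sits on the phenyl ring. Also open, as far as these compounds go, is how an amine or a carboxylic acid at this place would read in this assay.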